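This account rests on a few compounds, and the source may have more. Where it says the series, first, only, none or still open, it means among the compounds named here.

The account concerns three measured compounds and one still to be measured, all tested in a functional assay on MDA-MB-435 cells (Homo sapiens); a lower number here means a stronger inhibitor of growth, a higher number a weaker inhibitor of growth. Compound 1 `Cc1cc(C)c2c(O)cc(-c3ccc(Cl)cc3)nc2n1` gives 4070 nM. Compound 2 `COc1ccc(-c2cc(O)c3c(C)cc(C)nc3n2)cc1` differs from it by methoxy in place of chloro on an aromatic carbon; in this assay compound 2 gives 28800 nM. That change produced a 7.1-fold higher number from compound 1 to compound 2 (0.85 log units; beyond the scatter). Compound 3 `Cc1cnc2nc(-c3ccc(Cl)cc3)cc(O)c2c1` has a core that differs from that of compound 1 in a way not broken down here. In this assay compound 3 gives 603 nM, the lowest of the three numbers. Compound 4 `COc1ccc(-c2cc(O)c3cc(C)cnc3n2)cc1` has not yet been measured; it differs from compound 3 by methoxy in place of chloro on an aromatic carbon, the same change as from compound 1 to compound 2, made at the same place. The expectation for compound 4 rests on that single earlier step. Because a 7.1-fold higher number from compound 1 to compound 2 (0.85 log units; beyond the scatter) was seen when the same change was made, compound 4 is expected to show a 6.6-fold higher number from compound 3 to compound 4 (0.82 log units; beyond the scatter). Within the data shown here, since only one earlier instance of the change is known, the range is kept wide. Compound 4 is therefore estimated at 4000 nM, with a range from 1500 nM to 12000 nM.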

Compound 4, concentration for 50% growth inhibition: 1820 nM
Compound 4: middle estimate off by 2.2-fold (0.34 log units), on the high side; the range from low to high includes it.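

On the core of compound 3, methoxy in place of chloro again moved the number upward in this assay (a 3.0-fold higher number from compound 3 to compound 4 (0.48 log units; beyond the scatter)), so the direction of the change was the same on both cores shown. The sizes of the two steps cannot be told apart, which means the earlier step carried over to the second core without a difference that can be read from these data: the same change on two cores in this assay, a 7.1-fold higher number (0.85 log units; beyond the scatter) from compound 1 to compound 2 and a 3.0-fold higher number (0.48 log units; beyond the scatter) from compound 3 to compound 4, 2.3-fold (0.37 log units) apart, within the scatter of two such steps. Among these compounds, this does not show why the change has this outcome, nor does it establish a rule for the series, since it rests on only two pairs of compounds and one exchange of groups.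

The compounds shown leave open how an amine, a nitrile or a longer chain such as ethoxy would compare with chloro and methoxy at the same place on the aromatic ring. They also leave open whether the direction of the step would hold on a third core.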